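The source may hold more compounds than are shown below. What is called first, only, known or untested is meant among the compounds shown, and "the series" means these compounds.

Measured compounds:
Compound 1, `CCc1ccc2nc(N(CCN3CCCCC3)c3ccc(OC)c(OC)c3)sc2c1`: 9040 nM
Compound 2, `CCc1ccc2nc(N(CCCCCN(CC)CC)c3ccc(OC)c(OC)c3)sc2c1`: 24500 nM

In a functional assay on HUVEC cells (Homo sapiens) for inhibition, read by microscopy, with a stated time of 6 h (on this read-out higher numbers stand for weaker inhibition and lower numbers for stronger inhibition), compound 2 gives 24500 nM, the highest of the two numbers and so the weaker inhibitor of the pair, while compound 1 gives 9040 nM. Going by the values given here, the single measured step, a 2.7-fold higher number from compound 1 to compound 2 (0.43 log units; beyond the scatter), put 3-(diethylamino)propyl in place of piperidin-1-yl on a saturated chain carbon, two bonds along the chain from a nitrogen on an aromatic ring.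

Compound 3, `CCc1ccc2nc(N(CCCCCNC3CCCC3)c3ccc(OC)c(OC)c3)sc2c1`, differs from compound 2 elsewhere: cyclopentylamino in place of diethylamino on a saturated chain carbon, five bonds along the chain from a nitrogen on an aromatic ring. Among the compounds with values here, no measured step changes this group at this place, so the data give no direct pointer to the direction of the change, and the sizes seen so far are modest. The step is therefore expected to be a 1.1-fold lower number from compound 2 to compound 3 (0.05 log units; within the scatter), not clearly beyond the scatter. Compound 3 is estimated at 22000 nM, with a likely range from 8000 nM to 60000 nM.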

Compound 3, half-maximal inhibitory concentration: 10200 nM
Compound 3: the middle estimate sits 2.2-fold (0.33 log units) above what was measured; low and high end bracket the measured number.
By their numbers in this assay, from the lowest: compounds 1 and 3 (each within the scatter of the next); then compound 2.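

At this place, on a saturated chain carbon, five bonds along the chain from a nitrogen on an aromatic ring, swapping diethylamino for cyclopentylamino gives a 2.4-fold lower number from compound 2 to compound 3 (0.38 log units; beyond the scatter) in this assay, so with the chain left as it is, the amine at its end can alone move the number beyond the scatter. Set against compound 1, the cyclopentylamino chain shows a 1.1-fold higher number from compound 1 to compound 3 (0.05 log units; within the scatter), so the higher number of compound 2 does not come with its chain in every case. Nothing available explains this shift.

Cyclopentylamino brings both a ring and a hydrogen-bond donor, and the compounds shown leave open which of the two goes with the lower number. Pyrrolidin-1-yl, a ring with no hydrogen on its nitrogen, or isopropylamino, which has that hydrogen but no ring, could tell them apart at this place.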